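The source may hold more compounds than are shown below. What is called first, only, known or untested is meant among the compounds shown, and "the series" means these compounds.

Working notes on the series. Going by the values given here, compound 1 `O=C(Nc1sc2c(c1C(=O)NNc1ccccc1)CCCCC2)NS(=O)(=O)c1ccccc1` stands lowest of the three numbers so far in a functional assay on cells (Melanoma cell, Homo sapiens) for inhibition, with a stated time of 48 h (a higher number here means a weaker inhibitor of growth, a lower number a stronger inhibitor of growth), where compound 1 gives 32300 nM. Compound 2 `CN1CCN(C(=O)c2c(NC(=O)NS(=O)(=O)c3ccccc3)sc3c2CCCCC3)CC1` gives 61200 nM and compound 3 `CCCCNC(=O)c1c(NC(=O)NS(=O)(=O)c2ccccc2)sc2c1CCCCC2` gives 76700 nM. Compound 4 `O=C(Nc1sc2c(c1C(=O)N1CCN(c3ccccc3)CC1)CCCCC2)NS(=O)(=O)c1ccccc1` is not yet measured; it differs from compound 1 as follows: 4-phenylpiperazin-1-yl in place of anilinoamino on a carbonyl carbon.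

Among the compounds with values here, two measured steps bear on this change. Replacing anilinoamino on the same carbonyl carbon gave a 1.9-fold higher number from compound 1 to compound 2 (0.28 log units; within the scatter), while exchanging the anilino group gave a 2.4-fold higher number from compound 1 to compound 3 (0.38 log units; beyond the scatter). Both point to a somewhat higher number when the anilinoamino group is altered, only one of them beyond the scatter. For compound 4 a similar small step upward is therefore expected, a 1.7-fold higher number from compound 1 to compound 4 (0.23 log units; within the scatter), and compound 4 is estimated at 55000 nM with a range of 20000 nM to 150000 nM.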

Compound 4, concentration for 50% growth inhibition: 52300 nM
Estimate against measurement, compound 4: 1.1-fold (0.02 log units) above, within the range that was stated.
By their numbers in this assay, from the lowest: compounds 1, 4, 2 and 3 (each within the scatter of the next, the first and the last beyond it).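

With 4-phenylpiperazin-1-yl on the carbonyl carbon, a group with no hydrogen-bond donors replaces anilinoamino and gives a 1.6-fold higher number from compound 1 to compound 4 (0.21 log units; within the scatter) in this assay, so the donors of anilinoamino are not needed to stay within the scatter of compound 1. Compared with butylamino the same group gives a 1.5-fold lower number from compound 3 to compound 4 (0.17 log units; within the scatter) and phenyl in place of methyl on the ring amine nitrogen gives a 1.2-fold lower number from compound 2 to compound 4 (0.07 log units; within the scatter) and so compound 4 separates from none of the other three compounds. No measurement here offers an explanation for these steps. On these data alone, whether a carboxylic acid or a longer chain on this carbonyl carbon would move the number beyond the scatter of compound 1 stays open.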